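The source may hold more compounds than are shown below. What is called first, only, known or untested is meant among the compounds shown, and "the series" means these compounds.

Working notes on the series. In a functional assay on ACHN cells (Homo sapiens) for inhibition, read by sulforhodamine B assay (on this read-out lower numbers stand for stronger inhibition of growth and higher numbers for weaker inhibition of growth), compound 1 `COc1ccc(CN2CCC=C(CCC(=O)NO)C2=O)cc1` gives 1670 nM and compound 3 `O=C(CCC1=CCCN(CCCCc2cccc3ccccc23)C1=O)NO` gives 1820 nM. These two numbers lie within the scatter of each other, so compound 1 shares the low end of a very short scale with compound 3 and cannot be ranked against it. For compound 2 `O=C(CCC1=CCCN(Cc2ccc3ccccc3c2)C1=O)NO` the entry reads "not determined" (no result reported), so it adds nothing to the comparison.

Compound 4 `O=C(CCC1=CCCN(Cc2ccc(Br)cc2)C1=O)NO` keeps the core of compound 1 and carries bromo in place of methoxy on an aromatic carbon, para to a large group (bromo in place of methoxy on an aromatic carbon). Among the compounds with values here, no pair of measured compounds shows what a single change does in this assay, so the expectation rests on thin evidence. Compound 3, with a quite different group on the shared core, still reads 1820 nM, close to the number for compound 1. No step beyond the scatter is therefore expected, and no direction is favoured. The estimated change is a 1.1-fold lower number from compound 1 to compound 4 (0.05 log units; within the scatter). For compound 4 the expected value is 1500 nM, with an estimated range of 700 nM to 3300 nM.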

Compound 4, concentration for 50% growth inhibition: 2480 nM
The estimate for compound 4 lay 1.7-fold (0.22 log units) below the measured number; the measured number falls inside the stated range.
By their numbers in this assay, from the lowest: compounds 1, 3 and 4 (each within the scatter of the next).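

In this assay, within the data shown here, bromo in place of methoxy on an aromatic carbon, para to a large group, gives a 1.5-fold higher number from compound 1 to compound 4 (0.17 log units; within the scatter), which is the only step so far that changes a single place. The step lies within the scatter, so this read-out does not separate the two groups at this position, even though the change removes the oxygen and the one hydrogen-bond acceptor of methoxy. No measurement at hand speaks to the reason for this result.

Still open, from the compounds shown here alone, is whether another group at this position, such as an amine, a carboxylic acid or a longer alkoxy chain, would give a step beyond the scatter. Also open, going by these compounds, is whether the same exchange would give a similar step with a different group on the shared core, as in compound 3.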